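Fluorine pattern on the phenyl ring of the piperidine series

The compounds below may be only part of what the source reports. "The series", "measured", "known", "first", "only" and "open" are said of these compounds alone.

Of the compounds shown here, three of the shared core have been measured in a functional assay on CHO cells for positive allosteric modulation of metabotropic glutamate receptor 2 (Homo sapiens), with a stated time of 30 min; a lower number here means that less compound is needed, a higher number that more compound is needed for the effect. Compound 1 `N#Cc1c(N2CCC(c3ccccc3)CC2)ccn(CC2CC2)c1=O` gives 151 nM. Compound 2 `N#Cc1c(N2CCC(c3ccccc3F)CC2)ccn(CC2CC2)c1=O` gives 81 nM. Compound 3 `COc1ccc(C2CCN(c3ccn(CC4CC4)c(=O)c3C#N)CC2)cc1` gives 98 nM. Compound 3 holds the second highest of the three numbers; its nearest neighbour is compound 2, with a 1.2-fold higher number from compound 2 to compound 3 (0.08 log units; within the scatter), and its furthest is compound 1, with a 1.5-fold lower number from compound 1 to compound 3 (0.19 log units; within the scatter). All three therefore sit within the scatter of one another.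

Compound 4 `N#Cc1c(N2CCC(c3c(F)cccc3F)CC2)ccn(CC2CC2)c1=O` differs from compound 3 by 2,6-difluorophenyl in place of 4-methoxyphenyl on a saturated ring carbon. Going by the values given here, two measured steps bear on this change. The addition of fluoro in place of hydrogen on an aromatic carbon gave a 1.9-fold lower number from compound 1 to compound 2 (0.27 log units; within the scatter), and the exchange of the phenyl substituent pattern gave a 1.2-fold higher number from compound 2 to compound 3 (0.08 log units; within the scatter); both lie within the scatter. Among the compounds with values here, no compound with two fluoro groups on the phenyl ring has been measured, so the second fluoro adds an untested element. On the shown steps, the move to compound 4 is expected to bring no change beyond the scatter in this assay, written as a 1.1-fold lower number from compound 3 to compound 4 (0.04 log units; within the scatter). Compound 4 is accordingly estimated at 90 nM, with a range from 40 nM to 220 nM.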

Compound 4, half-maximal effective concentration: 31 nM
The estimate for compound 4 lay 2.9-fold (0.46 log units) above the measured number, and the stated range ends above it.
By their numbers in this assay, from the lowest: compound 4; then compounds 2, 3 and 1 (each within the scatter of the next).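

In this assay, going by these compounds alone, 2,6-difluorophenyl on the saturated ring carbon, three ring bonds from the ring nitrogen, is the first group here to give steps beyond the scatter, after compound 1, compound 2 and compound 3 had all remained within it of one another. Within the data shown here, compound 4 has the lowest number of the four, with all three steps to it beyond the scatter, though each is modest: against 4-methoxyphenyl (a 3.2-fold lower number from compound 3 to compound 4 (0.50 log units; beyond the scatter)), against the unsubstituted phenyl (a 4.9-fold lower number from compound 1 to compound 4 (0.69 log units; beyond the scatter)) and against the single fluoro (a 2.6-fold lower number from compound 2 to compound 4 (0.42 log units; beyond the scatter)), the last of these set against a first fluoro step that stayed within the scatter (a 1.9-fold lower number from compound 1 to compound 2 (0.27 log units; within the scatter)). No measurement available bears on what lies behind these steps.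

Open, going by these compounds, is whether the lower number belongs to the 2,6-difluorophenyl pattern itself, or would also come with other difluorophenyl patterns, or with a dichlorophenyl or dimethylphenyl group on the same saturated ring carbon. Also open, on these data alone, is whether the step would carry over if the nitrile of the shared core gave way to a primary amide or a carboxylic acid.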